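A Methyl Moved Around the Benzyl Ring

The source may hold more compounds than are shown below. What is called first, only, known or untested is meant among the compounds shown, and "the series" means these compounds.

Measured compounds:
compound 1, `O=C(O)c1ccccc1-c1ccc(CCc2ncc(Cc3ccccc3F)[nH]2)cc1`, 9.5 nM
compound 2, `CCCCc1cnc(CCc2ccc(-c3ccccc3C(=O)O)cc2)[nH]1`, 93 nM
compound 3, `Cc1cccc(Cc2cnc(CCc3ccc(-c4ccccc4C(=O)O)cc3)[nH]2)c1`, 75 nM

In an in vitro functional assay on cells for agonist activity at Bombesin receptor subtype-3 (Mus musculus), read by luminescence and calcium flux (on this read-out lower numbers stand for an effect already at smaller amounts and higher numbers for an effect only at larger amounts of compound), compound 3 gives 75 nM, the second highest of the three numbers. Compound 2 sits nearest with 93 nM, and compound 1 lies furthest with 9.5 nM. Compound 4, `Cc1ccc(Cc2cnc(CCc3ccc(-c4ccccc4C(=O)O)cc3)[nH]2)cc1`, is the unmeasured partner of compound 3: 4-methylphenyl in place of 3-methylphenyl on a saturated chain carbon bound to an aromatic carbon. Within the data shown here, all the measured steps alter the same saturated chain carbon: a 9.8-fold higher number from compound 1 to compound 2 (0.99 log units; beyond the scatter), a 7.9-fold higher number from compound 1 to compound 3 (0.90 log units; beyond the scatter) and a 1.2-fold lower number from compound 2 to compound 3 (0.09 log units; within the scatter). None of them shifts a methyl within a phenyl ring; the nearest guide is that exchanging one group for another of similar size at this place left the number within the scatter from compound 2 to compound 3. The expected step is therefore none beyond the scatter, a 1.1-fold higher number from compound 3 to compound 4 (0.03 log units; within the scatter). For compound 4 the estimate is 80 nM, with a range from 30 nM to 250 nM.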

Compound 4, half-maximal effective concentration: 162 nM
For compound 4 the middle estimate is 2.0-fold (0.31 log units) below the measured one; the measured number falls inside the stated range.
By their numbers in this assay, from the lowest: compound 1; then compounds 3, 2 and 4 (each within the scatter of the next, the first and the last beyond it).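

Moving the methyl around the benzyl ring keeps every atom and still shifts the number: in this assay the change from 3-methylbenzyl to 4-methylbenzyl gives a 2.2-fold higher number from compound 3 to compound 4 (0.33 log units; beyond the scatter) as a modest step, so this place on a saturated chain carbon bound to an aromatic carbon responds to where a methyl sits on the ring and not only to which group stands there. The ring does not by itself set the number: a 1.7-fold higher number from compound 2 to compound 4 (0.24 log units; within the scatter) stays within the scatter, so 4-methylphenyl cannot be told apart from propyl, whereas a 17-fold higher number from compound 1 to compound 4 (1.23 log units; beyond the scatter) is the largest step among these compounds. No available evidence bears on why the methyl shift changes the number.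

The compounds shown leave open whether the lower number of compound 1 follows from fluorine itself or from its place on the ring, as compound 1 is the only fluorophenyl among them. They also leave open how a methoxy group, a chlorine atom or an amine on the benzyl ring would read at this place.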